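Same aryl swap, two cores, solubility

The source may hold more compounds than are shown below. What is called first, only, known or untested is meant among the compounds shown, and "the series" means these compounds.

The measured compounds:
compound 1 `CCCN(Cc1ccc(OCCn2c(=O)ccn(C)c2=O)c(OC)c1)C(CC(=O)O)c1ccc(Cl)cc1`: 3000000 nM
compound 2 `CCCN(Cc1ccc(OCCn2c(=O)ccn(C)c2=O)c(OC)c1)C(CC(=O)O)c1ccc2c(c1)CCO2`: 3000000 nM
compound 3 `COc1cc(CN(CC(C)C)C(CC(=O)O)c2ccc3c(c2)CCO3)ccc1OCCN1C(=O)CCC1=O`: 3000000 nM

All three were measured in a physicochemical assay for solubility, at pH 1.1; a higher number here means a more soluble compound, a lower number a less soluble compound. In this assay compound 1 gives 3000000 nM, compound 2 gives 3000000 nM and compound 3 gives 3000000 nM, so the three stand level with one another.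

Compounds 1 and 2 share a core and differ in one place: a group of 7 heavy atoms (6 carbon, 1 chlorine; one six-membered aromatic ring of carbon only) in place of a group of 9 heavy atoms (8 carbon, 1 oxygen; one five-membered non-aromatic ring with 1 hetero atom, one six-membered aromatic ring of carbon only), on a saturated chain carbon bound to an amine nitrogen and a saturated chain carbon. The step that this change made is no change at the digits printed from compound 2 to compound 1 (within the scatter).

Compound 3 sits on a different core; the difference between the two cores is not broken down here. The unmeasured compound 4 `COc1cc(CN(CC(C)C)C(CC(=O)O)c2ccc(Cl)cc2)ccc1OCCN1C(=O)CCC1=O` is made from compound 3 by the same change: a group of 7 heavy atoms (6 carbon, 1 chlorine; one six-membered aromatic ring of carbon only) in place of a group of 9 heavy atoms (8 carbon, 1 oxygen; one five-membered non-aromatic ring with 1 hetero atom, one six-membered aromatic ring of carbon only), on a saturated chain carbon bound to an amine nitrogen and a saturated chain carbon. The place of the change reads identically in both pairs, so the change is the same, only on another core.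

The expectation for compound 4 rests on compound 3, whose own value is 3000000 nM, and on the earlier step of no change at the digits printed from compound 2 to compound 1 (within the scatter). Applied to compound 3, the change is expected to give a step of no change at the digits printed from compound 3 to compound 4 (within the scatter), since the same change left compound 1 level with compound 2. Compound 4 is therefore estimated at 3000000 nM in this assay, with a likely range from 1500000 nM to 3000000 nM. Whether a second core would behave differently cannot be checked against the compounds shown, since the change has been measured on one core only.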

Compound 4, solubility: 3000000 nM
Beside the measured number, compound 4's estimate shows no gap at the digits printed, within the range that was stated.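

The new step is no change at the digits printed from compound 3 to compound 4 (within the scatter) in this assay, and it agrees with the earlier no change at the digits printed from compound 2 to compound 1 (within the scatter), so in these two pairs, putting 4-chlorophenyl in place of the group with the five-membered ring leaves the printed solubility unchanged on both cores. Among the compounds shown here, this does not show that the change will stay without effect on every core: it rests on only two pairs, and all four compounds print the same value, so this set offers no spread against which a difference between the cores could show itself. Nothing shown here gives a reason for this agreement, so the result stands as an observation without an explanation.

The compounds shown leave open whether the same level reading would hold on a third core, or if a group such as nitrile or trifluoromethyl entered at the same saturated chain carbon on a six-membered aromatic ring in place of 4-chlorophenyl. For the compounds shown here, they also leave open how the two cores compare with each other, as compounds on different cores differ in more than one place and no single step between them can be read.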